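A few compounds are considered here, and "the series" means these few. Any claim that something is new, unique, unknown or untested is made for them only; others in the source may bear on it.

Two compounds of this series have been run so far in a functional assay on the whole organism (strain albino) for inhibition, with Rattus norvegicus as the target, read by paw edema, with stated times of 30 min and 3 h, at a dose of 50 mg/kg by the oral route; on this read-out lower numbers stand for less inhibition and higher numbers for more inhibition at the one dose given (going by the name of the read-out). Compound 1, `CC1CC(O)N(Cc2ccncc2)C(=S)N1`, gives 30%. Compound 2, `CC1=CC(C)(C)NC(=S)N1c1cc(C#N)ccc1N`, gives 32% in this assay. Among the measured compounds shown here, the numbers of compound 2 and compound 1 lie within the usual scatter of each other, so the two compounds are not separated by these data, and no step between them can be drawn from what has been measured.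

Compound 3, `CC1=CC(C)(C)NC(=S)N1c1cc(Br)ccc1N`, has not yet been measured. It differs from compound 2 in one place: bromo in place of cyano on an aromatic carbon. Nothing in the measured pair shows how a change of this kind acts on paw edema inhibition, so the expectation rests on the value of compound 2 alone and on the small size of the change. In this assay the expected step is a number 2 percentage points lower from compound 2 to compound 3 (within the scatter), that is, no shift beyond the scatter in either direction. On this basis compound 3 is expected to give about 30% in this assay, with a range from 15% to 45%.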

Compound 3, a percentage reported as inhibition, in the whole organism at one dose (the size of the read-out at that dose, not a potency): 31%
Compound 3: the middle estimate sits 1 percentage points below what was measured, and the stated range covers the measured number.
By their numbers in this assay, from the lowest: compounds 1, 3 and 2 (each within the scatter of the next).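

In this assay, among the compounds shown here, the exchange at the aromatic carbon para to an amino group and meta to a large group gives a number 1 percentage points lower from compound 2 to compound 3 (within the scatter), the first step that can be read at a single place. Cyano, with its triple bond and hydrogen-bond acceptor, and bromo, with neither, are therefore not separated at this position by this read-out at the one oral dose, which reports the size of the effect and not a potency. No measured evidence bears on why the two groups are not separated.

The compounds shown leave open whether any group at this carbon moves the read-out beyond the scatter: a carboxylic acid, a methoxy group or a longer chain in place of bromo could answer that, and so could a plain hydrogen. They also leave open how far the amino group on the same ring matters, since a pair differing only there, such as one with an acetamide in its place, is absent from the compounds shown.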